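Amino for hydroxy on the chloro-bearing analogue

This account rests on a few compounds, and the source may have more. Where it says the series, first, only, none or still open, it means among the compounds named here.

Compound 1 `Oc1ccccc1-c1nnn[nH]1` gives 700000 nM in an assay on cells for inhibition of Indoleamine 2,3-dioxygenase 1 (Homo sapiens), read by HPLC, with a stated time of 20 min; a higher number here means a weaker inhibitor, a lower number a stronger inhibitor. Compound 2 `Nc1ccccc1-c1nnn[nH]1` gives 5800 nM in this assay, and compound 3 `Oc1ccc(Cl)cc1-c1nnn[nH]1` gives 16000 nM in this assay. Compound 3 thus stands second highest of the three numbers, with compound 2 lower and compound 1 far higher. Compound 4 `Nc1ccc(Cl)cc1-c1nnn[nH]1` carries amino in place of hydroxy on an aromatic carbon. The same exchange was seen once, as a 120-fold lower number from compound 1 to compound 2 (2.08 log units; beyond the scatter), a large step; the chloro addition gave a 44-fold lower number from compound 1 to compound 3 (1.64 log units; beyond the scatter). Both steps on compound 1 ran in the same direction, so the exchange on compound 3 is expected to lower the number again, perhaps by somewhat less than on compound 1. Compound 4 is therefore estimated at 300 nM, between 60 nM and 1500 nM. The expected step is a 53-fold lower number from compound 3 to compound 4 (1.73 log units; beyond the scatter).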

Compound 4, half-maximal inhibitory concentration: 220 nM
Compound 4: the middle estimate sits 1.4-fold (0.13 log units) above what was measured; low and high end bracket the measured number.
By their numbers in this assay, from the lowest: compound 4; then compound 2; then compound 3; then compound 1.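

The exchange of amino for hydroxy again gives a large step, a 73-fold lower number from compound 3 to compound 4 (1.86 log units; beyond the scatter), so its effect is not confined to the core of compound 1: the same change on two cores in this assay, a 120-fold lower number (2.08 log units; beyond the scatter) from compound 1 to compound 2 and a 73-fold lower number (1.86 log units; beyond the scatter) from compound 3 to compound 4, 1.7-fold (0.22 log units) apart, within the scatter of two such steps. The chloro group also keeps a large step with amino in place of hydroxy, a 26-fold lower number from compound 2 to compound 4 (1.42 log units; beyond the scatter): the same change on two cores in this assay, a 44-fold lower number (1.64 log units; beyond the scatter) from compound 1 to compound 3 and a 26-fold lower number (1.42 log units; beyond the scatter) from compound 2 to compound 4, 1.7-fold (0.22 log units) apart, within the scatter of two such steps. Across these four compounds, the two changes therefore combine with little loss of either step. Open, as far as these compounds go, is whether a methylamino or acetamido group could replace the amino group, or a bromo or methoxy group the chloro group, with a similar step.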